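Chloro to Fluoro Carried from One Core to Another

The compounds below may be only part of what the source reports. "The series", "measured", "known", "first", "only" and "open" are said of these compounds alone.

Compound 1 `Fc1cc(Nc2cc(Nc3ccc(Cl)cc3)ncn2)ccc1Oc1ccncc1-c1cccnc1` and compound 2 `Fc1ccc(Nc2cc(Nc3ccc(Oc4ccncc4-c4cccnc4)c(F)c3)ncn2)cc1` share one core, while compound 3 `O=C(Nc1ccc(Oc2ccncc2-c2cccnc2)c(F)c1)c1ccnn(-c2ccc(Cl)cc2)c1=O` and compound 4 `O=C(Nc1ccc(Oc2ccncc2-c2cccnc2)c(F)c1)c1ccnn(-c2ccc(F)cc2)c1=O` share another. How the core of compound 3 differs from the core of compound 1 is not broken down here.

In a functional assay on MKN-45 cells (Homo sapiens) for cytotoxicity, read by MTT assay, with a stated time of 72 h (a higher number here means a weaker inhibitor, a lower number a stronger inhibitor), compound 1 gives 240 nM. In this assay compound 2 gives 160 nM. In this assay compound 3 gives 4230 nM, the highest of the three numbers and beyond the scatter from both of the others.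

Within the first pair, the difference from compound 1 to compound 2 is fluoro in place of chloro on an aromatic carbon. This change made a 1.5-fold lower number from compound 1 to compound 2 (0.18 log units; within the scatter).

Within the second pair, the difference from compound 3 to compound 4 is fluoro in place of chloro on an aromatic carbon. The place of the change reads the same as in the first pair, so the same change is now made on the other core, where the starting number is far higher.

Among the compounds with values here, only the one earlier example of this change is available, and it was within the scatter. On that basis the step from compound 3 to compound 4 is expected to be a 1.2-fold lower number from compound 3 to compound 4 (0.08 log units; within the scatter), because the same change from compound 1 to compound 2 gave a 1.5-fold lower number from compound 1 to compound 2 (0.18 log units; within the scatter). In this assay compound 4 is expected to give 3500 nM, with a likely span from 1500 nM to 9000 nM.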

Compound 4, half-maximal inhibitory concentration: 3120 nM
Compound 4: middle estimate off by 1.1-fold (0.05 log units), on the high side; the measured number falls inside the stated range.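

In this assay, the change from 4-chlorophenyl to 4-fluorophenyl on the second core gives a 1.4-fold lower number from compound 3 to compound 4 (0.13 log units; within the scatter), so the step again stays inside the usual scatter of repeated measurements. Set beside the earlier example, the two steps agree: the same change on two cores in this assay, a 1.5-fold lower number (0.18 log units; within the scatter) from compound 1 to compound 2 and a 1.4-fold lower number (0.13 log units; within the scatter) from compound 3 to compound 4, 1.1-fold (0.04 log units) apart, within the scatter of two such steps

This shows that, in these two pairs, the exchange of chloro for fluoro on an aromatic carbon carries from one core to the other without a change that can be told from the scatter, even though the two cores start from very different numbers. It does not show that fluoro gives any real gain on either core, as neither step is beyond the scatter, and two pairs cannot establish that the same would hold on a third core.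

The compounds shown leave open how a methoxy group, a nitrile or an amine would behave in place of the halogen on either core, and whether a bromo group would follow chloro and fluoro. Within the data shown here, they also leave open which part of the core of compound 3 sets its number so far from that of compound 1, as those two compounds differ in more than one place.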